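This account rests on a few compounds, and the source may have more. Where it says the series, first, only, none or still open, it means among the compounds named here.

Among the measured compounds shown here, compound 2 `C/C(CC(=O)Nc1nnc(-c2ccc(O)cc2)s1)=N\c1ccccn1` gives 3.43 in a physicochemical assay for lipophilicity, measured as octanol-water partition (a lower number here means a more polar compound, a higher number a more lipophilic compound), the second highest of the three numbers measured so far. The nearest number belongs to compound 1 `C/C(CC(=O)Nc1nnc(-c2ccc(O)cc2)s1)=N\c1ccc([N+](=O)[O-])cn1`, which gives 3.34, and the furthest to compound 3 `CC(=O)Oc1ccccc1-c1nnc(NC(=O)C/C(C)=N/c2ccc([N+](=O)[O-])cn2)s1`, which gives 3.56; both gaps lie within the usual scatter. Compound 4 `C/C(CC(=O)Nc1nnc(-c2ccc([N+](=O)[O-])cc2)s1)=N\c1ccccn1` has not yet been measured. It differs from compound 2 by nitro in place of hydroxy on an aromatic carbon. For the measured compounds named here, two measured steps bear on this change. The step of a number 0.09 log units higher from compound 1 to compound 2 (within the scatter) takes a nitro group away, and the step of a number 0.22 log units higher from compound 1 to compound 3 (within the scatter) takes a hydroxy group away while bringing in an acetoxy; neither moved this assay beyond the scatter. Because a number 0.09 log units higher from compound 1 to compound 2 (within the scatter) and a number 0.22 log units higher from compound 1 to compound 3 (within the scatter) were both small, the exchange of a hydroxy for a nitro is expected to give at most a modest rise in this assay, and possibly nothing beyond the scatter. Compound 4 is therefore estimated at 3.7 in this assay, with a range from 3.3 to 4.1. This estimate corresponds to an expected step of a number 0.27 log units higher from compound 2 to compound 4 (within the scatter).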

Compound 4, partition coefficient: 3.63
Compound 4: the middle estimate sits 0.07 log units above what was measured; the range from low to high includes it.
By their numbers in this assay, from the lowest: compounds 1, 2, 3 and 4 (each within the scatter of the next).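

Among the compounds shown here, this is the first exchange made directly on the 4-hydroxyphenyl group with the rest of compound 2 kept, and in this assay nitro in place of hydroxy, para to a large group, gives a number 0.20 log units higher from compound 2 to compound 4 (within the scatter). A hydrogen-bond donor leaves with the hydroxy and none enters with the nitro, yet the step stays within the scatter. Read beside a number 0.09 log units higher from compound 1 to compound 2 (within the scatter), it shows that, in these compounds, changes involving a nitro group on either of the two aromatic rings have not moved this number beyond the scatter.

Nothing shown here accounts for the size of this step. Going by these compounds, whether an amine or a carboxylic acid at this same place would move the number beyond the scatter remains open.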